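Metabolic stability notes: pyrazole ureas and amides

The source may hold more compounds than are shown below. What is called first, only, known or untested is meant among the compounds shown, and "the series" means these compounds.

Measured so far:
compound 1 `O=C(Nc1cc(-c2ccccn2)n[nH]1)N1CCC(Oc2ccccc2)CC1` — 98.5 mL.min-1.g-1
compound 2 `O=C(Nc1[nH]nc(-c2ccccn2)c1C1CC1)c1c(Cl)cccc1Cl` — > 100 mL.min-1.g-1
compound 3 `O=C(NCc1ccccc1)Nc1[nH]nc(-c2ccccn2)c1Cl` — > 400 mL.min-1.g-1

Going by the values given here, in an ADME assay on liver (Mesocricetus auratus) for metabolic stability, using microsomes (a lower number here means slower removal, a higher number faster removal of the compound), compound 1 gives 98.5 mL.min-1.g-1, the only plain number in the set. For compound 2 this assay reports a limit of > 100 mL.min-1.g-1. For compound 3 it likewise reports a limit of > 400 mL.min-1.g-1. No two of these compounds differ in a single place, so no step is counted among them.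

Compound 4 `O=C(Nc1cc(-c2ccccn2)n[nH]1)N1CCC(c2cccc(F)c2)CC1` differs from compound 1 by 3-fluorophenyl in place of phenoxy on a saturated ring carbon. Among the compounds with values here, with no measured step to lean on, the expected change from compound 1 to compound 4 is small, within the usual scatter: a 1.2-fold higher number from compound 1 to compound 4 (0.07 log units; within the scatter). Compound 4 is therefore estimated at 115 mL.min-1.g-1, between 55 mL.min-1.g-1 and 240 mL.min-1.g-1.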

Compound 4, intrinsic clearance in microsomes: 207 mL.min-1.g-1
Compound 4: middle estimate off by 1.8-fold (0.26 log units), on the low side; the range from low to high includes it.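

The series now has one readable step: at this saturated ring carbon, three ring bonds from the ring nitrogen, this assay shows a 2.1-fold higher number from compound 1 to compound 4 (0.32 log units; beyond the scatter). The leaving and entering groups match in heavy atoms and in their aromatic ring, so this position responds to an exchange that leaves both of those unchanged. Nothing measured here accounts for the step.

From the compounds shown here alone, whether the step follows from losing the phenoxy oxygen or from gaining the fluorine stays open. A plain phenyl or a 3-fluorophenoxy group on this carbon would separate the two.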